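The source may report more compounds than this note shows. Statements on the series, on what has been measured and on what is new or still open speak of the compounds shown alone.

Measured compounds in a functional assay on the whole organism (stomach) for inhibition, with Rattus norvegicus as the target, at a dose of 80 mg/kg; on this read-out lower numbers stand for less inhibition and higher numbers for more inhibition at the one dose given (going by the name of the read-out):
- compound 1 `CC(C)c1ccc(-c2cc(=O)c3cc(C(=O)O)ccc3o2)cc1`: 19%
- compound 2 `CCCCCCc1ccc(-c2cc(=O)c3cc(C(=O)O)ccc3o2)cc1`: 2%
- compound 3 `COc1ccc(-c2cc(=O)c3cc(C(=O)O)ccc3o2)cc1`: 13%

Compound 3 sits second highest of the three numbers in this assay. Its nearest neighbour is compound 1, and the gap a number 6 percentage points lower from compound 1 to compound 3 (within the scatter) lies within the scatter, so the two cannot be ordered. Against compound 2 the gap a number 11 percentage points higher from compound 2 to compound 3 (beyond the scatter) is beyond the scatter, though modest. The third step, a number 17 percentage points lower from compound 1 to compound 2 (beyond the scatter), is the largest seen in the set and again modest.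

Compound 4 `COc1ccc(-c2oc3ccc(C(=O)O)cc3c(=O)c2OC(C)C)cc1` differs from compound 3 as follows: isopropoxy in place of hydrogen on an aromatic carbon. The change sits on an aromatic carbon of a six-membered aromatic ring with 1 oxygen, part of a fused or bridged system of two rings, two atoms from the ring oxygen. For the measured compounds named here, none of the measured steps touches this ring; all three alter only the group on the aromatic carbon of the outer phenyl. Going by the values given here, no measured step therefore bears directly on the change from compound 3 to compound 4, and the set gives no precedent for adding a group on the core of compound 3.

With nothing to draw on beyond the spread of the measured numbers, the expectation for compound 4 is a step of no change at the digits printed from compound 3 to compound 4 (within the scatter), that is, none beyond the scatter. Compound 4 is estimated at 13%, with a range from 0% to 30%.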

Compound 4, a percentage reported as inhibition, in the whole organism at one dose (the size of the read-out at that dose, not a potency): 35%
Beside the measured number, compound 4's estimate is 22 percentage points below it, outside the stated range (above it).
By their numbers in this assay, from the lowest: compound 2; then compounds 3 and 1 (each within the scatter of the next); then compound 4.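

In this assay, for the compounds shown here, the first change on the core itself, isopropoxy in place of hydrogen on the aromatic carbon ortho to a 4-methoxyphenyl group and two atoms from the ring oxygen, gives a number 22 percentage points higher from compound 3 to compound 4 (beyond the scatter). Going by these compounds alone, the earlier steps, such as a number 17 percentage points lower from compound 1 to compound 2 (beyond the scatter), altered only the group on the outer phenyl, so this is the first sign that the read-out also responds to a substituent on the core, and that this position accepts a group of this size with no loss at the one dose given. This rests on a single pair, and nothing at hand bears on what lies behind the rise.

Going by these compounds, it remains open whether the gain belongs to isopropoxy in particular or to any group at this carbon, and a hydroxyl, an ethoxy, a longer alkoxy chain or an amine here would separate those readings. Also open, on these data alone, is whether the same isopropoxy gives a similar step when the 4-methoxyphenyl group is replaced by the isopropyl or hexyl analogues of compound 1 and compound 2, and whether the step holds at other doses.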